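A few compounds are considered here, and "the series" means these few. Any claim that something is new, unique, unknown or untested is made for them only; others in the source may bear on it.

Compound 1 `O=C(O)c1cn(C2CC2)c2c(F)c(N3CCCC3)c(F)cc2c1=O` gives 120 ug/mL in a functional assay on V79 cells (Cricetulus griseus) for cytotoxicity, read by colony formation; a higher number here means a weaker inhibitor, a lower number a stronger inhibitor. That sits within the scatter of compound 2 `O=C(O)c1cn(C2CC2)c2c(Cl)c(N3CCCC3)c(F)cc2c1=O` at 150 ug/mL and compound 3 `COc1c(N2CCCC2)c(F)cc2c(=O)c(C(=O)O)cn(C3CC3)c12` at 150 ug/mL. Compound 4 `CNCC1(C)CCN(c2c(F)cc3c(=O)c(C(=O)O)cn(C4CC4)c3c2F)C1` keeps the core of compound 1 but replaces its pyrrolidin-1-yl group: 3-methyl-3-((methylamino)methyl)pyrrolidin-1-yl in place of pyrrolidin-1-yl on an aromatic carbon. The measured steps offer only indirect help, since they exchange other groups on an aromatic carbon: a 1.3-fold higher number from compound 1 to compound 2 (0.10 log units; within the scatter), a 1.3-fold higher number from compound 1 to compound 3 (0.10 log units; within the scatter) and no change at the digits printed from compound 2 to compound 3 (within the scatter), all within the scatter. None touches the pyrrolidin-1-yl group, so the data give no firm direction for this change, and a modest move to a lower number in this assay is only a tentative expectation. The expected step is a 2.0-fold lower number from compound 1 to compound 4 (0.30 log units; within the scatter). Compound 4 is estimated at 60 ug/mL, with an expected range from 15 ug/mL to 200 ug/mL.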

Compound 4, half-maximal inhibitory concentration: 8 ug/mL
The estimate for compound 4 lay 7.5-fold (0.88 log units) above the measured number; measured number below the stated range.
By their numbers in this assay, from the lowest: compound 4; then compounds 1, 2 and 3 (each within the scatter of the next).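

In this assay, the group on this aromatic carbon has a large effect: 3-methyl-3-((methylamino)methyl)pyrrolidin-1-yl in place of pyrrolidin-1-yl gives a 15-fold lower number from compound 1 to compound 4 (1.18 log units; beyond the scatter), making compound 4 the stronger inhibitor. The earlier exchanges among fluoro, chloro and methoxy on another aromatic carbon all stayed within the scatter, so this is the first change shown to move the number clearly. Nothing available explains the shift.

Going by these compounds, the methyl and the methylamino parts enter together, so it remains open which one carries the step. Also open, on these data alone, is whether a plain aminomethyl group or a piperazine ring here would act the same way.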